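This account rests on a few compounds, and the source may have more. Where it says the series, first, only, none or still open, it means among the compounds named here.

In a functional assay on MCF7 cells (Homo sapiens) for inhibition, read by MTT assay, with a stated time of 72 h; a higher number here means a weaker inhibitor, a lower number a stronger inhibitor:
- compound 1 `C=C(Br)C(=O)Nc1cccc(/C=C/C(=O)Nc2ccc(Cl)cc2)c1`: 11000 nM
- compound 2 `C=C(Br)C(=O)Nc1cccc(/C=C/C(=O)Nc2ccc(C)cc2)c1`: 2500 nM

Of these two, compound 2 has the lower number, at 2500 nM. The next structure is compound 3 `C=C(Br)C(=O)Nc1cccc(/C=C/C(=O)Nc2ccc(OC(F)(F)F)cc2)c1`, with trifluoromethoxy in place of methyl on an aromatic carbon, para to a large group: trifluoromethoxy in place of methyl on an aromatic carbon.

For the measured compounds named here, only one measured step bears on this change, and it concerns the same place: a 4.4-fold lower number from compound 1 to compound 2 (0.64 log units; beyond the scatter). That step is modest, and trifluoromethoxy itself has not been measured on this core. With only compound 1 at 11000 nM as a reference for replacing the methyl, a modest rise in this assay is expected, with low confidence in its direction. The expected change is a 2.2-fold higher number from compound 2 to compound 3 (0.34 log units; beyond the scatter). For compound 3 the estimated value is 5500 nM, with an expected range of 1800 nM to 16000 nM.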

Compound 3, half-maximal inhibitory concentration: 43300 nM
Estimate against measurement, compound 3: 7.9-fold (0.90 log units) below; the whole stated range lies below it.
By their numbers in this assay, from the lowest: compound 2; then compound 1; then compound 3.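

In this assay, for the compounds shown here, the aromatic position para to a large group proves more sensitive than the one earlier step could show: trifluoromethoxy in place of methyl gives a large rise (a 17-fold higher number from compound 2 to compound 3 (1.24 log units; beyond the scatter)), and trifluoromethoxy in place of chloro gives a modest one (a 3.9-fold higher number from compound 1 to compound 3 (0.60 log units; beyond the scatter)). Compound 3 therefore has the highest number of the three, with steps to both others beyond the scatter, so the order runs methyl, then chloro, then trifluoromethoxy, and the two-compound comparison alone gave no sign of how far a replacement could push the number up. No supporting data explain this order.

As far as these compounds go, it remains open how an amine, a carboxylic acid or a plain hydrogen would read at this place on the shared core. From the compounds shown here alone, it also remains open whether a longer chain such as ethyl or methoxy would stay close to methyl or move toward trifluoromethoxy.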